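Naphthoquinone carbinols: swapping the alkenyl arm for fluorophenyl

A few compounds are considered here, and "the series" means these few. Any claim that something is new, unique, unknown or untested is made for them only; others in the source may bear on it.

Measured compounds:
compound 1, `CC(C)=CC(O)C1=CC(=O)c2ccccc2C1=O`: 5200 nM
compound 2, `O=C1C=C([C@@H](O)c2ccccc2)C(=O)c2ccccc21`: 3800 nM

In a functional assay on WHCO1 cells (Homo sapiens) for cytotoxicity, read by MTT assay, with a stated time of 24 h (on this read-out higher numbers stand for weaker inhibition and lower numbers for stronger inhibition), compound 1 gives the higher of the two numbers shown, but compound 2 sits within the scatter of it, so neither stands apart. Compound 3, `O=C1C=C(C(O)c2ccc(F)cc2)C(=O)c2ccccc21`, has not been measured. It differs from compound 1 by 4-fluorophenyl in place of 2-methylprop-1-en-1-yl on a saturated chain carbon bound to a double-bonded ring carbon and an oxygen on a saturated carbon. Among the compounds with values here, no step between measured compounds is known for this change; the number for compound 2 suggests little movement. The step from compound 1 to compound 3 is expected to be small, near the scatter, as a 1.4-fold lower number from compound 1 to compound 3 (0.16 log units; within the scatter). Compound 3 is estimated at 3600 nM, within 1500 nM to 9000 nM.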

Compound 3, half-maximal inhibitory concentration: 5100 nM
Beside the measured number, compound 3's estimate is 1.4-fold (0.15 log units) below it; low and high end bracket the measured number.
By their numbers in this assay, from the lowest: compounds 2, 3 and 1 (each within the scatter of the next).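

On the saturated chain carbon bound to a double-bonded ring carbon and an oxygen on a saturated carbon, replacing 2-methylprop-1-en-1-yl with 4-fluorophenyl gives in this assay a 1.0-fold lower number from compound 1 to compound 3 (0.01 log units; within the scatter) as the measured step. At this position, then, an aromatic ring carrying fluorine can stand in for the alkenyl arm without a shift beyond the scatter. No available evidence explains this result.

On these data alone, whether an amine or a carboxylic acid on the aromatic ring, or a longer alkyl chain at this carbon, would keep the number in this range remains open.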